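Replacing a Nitro Group and Watching Cytotoxicity

A few compounds are considered here, and "the series" means these few. Any claim that something is new, unique, unknown or untested is made for them only; others in the source may bear on it.

This account follows a single change made to compound 1 `COc1cc2ncnc(-n3nc(-c4ccccn4)nc3N)c2cc1[N+](=O)[O-]`, read against an ADME assay on BJ cells (Homo sapiens) for cytotoxicity, with a stated time of 72 h; on this read-out lower numbers stand for an effect already at smaller amounts and higher numbers for an effect only at larger amounts of compound. For compound 1 the result in this assay is only a limit, > 13000 nM, not a number (the limit of > 13000 nM in this assay, at which 1 of the 3 values shown sits). Two companions stand alongside it. Compound 3 `COc1cc2ncnc(-n3nc(-c4ccc(Cl)cc4)nc3N)c2cc1OC` likewise returns only a limit in this assay, > 50000 nM (the limit of > 50000 nM in this assay, at which 1 of the 3 values shown sits). Compound 2 `Nc1nc(-c2ccccn2)nn1-c1ncnc2cc(N3CCNCC3)c([N+](=O)[O-])cc12` has no result in this assay, "not determined" (no result reported). Compound 1 therefore stands as one of two entries that ended at a limit, with the third entry lacking a number altogether, so no measured step connects any pair of these compounds.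

The new compound is compound 4 `COc1cc2ncnc(-n3nc(-c4ccccn4)nc3N)c2cc1OCCCNC(=O)C(F)(F)F`. It differs from compound 1 in one place: 3-(((trifluoromethyl)carbonyl)amino)propoxy in place of nitro on an aromatic carbon. The nitro group leaves and the 3-(((trifluoromethyl)carbonyl)amino)propoxy group enters, on the aromatic carbon ortho to the methoxy group.

With both measured values sitting at limits, no direction can be read from the data, and the step in this assay is expected to come out as a step that the limit leaves unreadable from compound 1 to compound 4, nothing beyond the usual scatter. Compound 4 is accordingly expected to give 30000 nM in this assay, within a range from 10000 nM to 100000 nM, and most likely to end again at a limit rather than at a number.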

Compound 4, half-maximal effective concentration: > 7000 nM
Compound 4 gave a limit, no number; the forecaster's own chance of this, stated with the estimate: 70%; the middle value does not contradict the limit.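

In this assay compound 4 gives > 7000 nM, which is a limit and not a number. Among these compounds, compound 1 also ended at a limit, so no step between compound 1 and compound 4 can be read. The compounds shown leave open whether 3-(((trifluoromethyl)carbonyl)amino)propoxy in place of nitro shifts the read-out at all, and in which direction.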